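Bromo to Iodo on the Triazole Aryl of Compound 3

A few compounds are considered here, and "the series" means these few. Any claim that something is new, unique, unknown or untested is made for them only; others in the source may bear on it.

Measured so far:
compound 1 `COc1ccc(-n2cc(COc3cccc(NC(=O)Nc4ccc(Cl)c(C(F)(F)F)c4)c3)nn2)cc1`: 4680 nM
compound 2 `CCc1ccc(-n2cc(COc3cccc(NC(=O)Nc4ccc(Cl)c(C(F)(F)F)c4)c3)nn2)cc1`: 1950 nM
compound 3 `O=C(Nc1cccc(OCc2cn(-c3ccccc3Br)nn2)c1)Nc1ccc(Cl)c(C(F)(F)F)c1`: 2810 nM

All three compounds share one core and differ only in the aryl group carried on the triazole nitrogen. In a functional assay on HepG2 cells (Homo sapiens) for inhibition, read by MTT assay, with a stated time of 72 h (on this read-out higher numbers stand for weaker inhibition and lower numbers for stronger inhibition), compound 1 gives 4680 nM, compound 2 gives 1950 nM and compound 3 gives 2810 nM. For the measured compounds named here, the one change that reaches beyond the scatter is a 2.4-fold lower number from compound 1 to compound 2 (0.38 log units; beyond the scatter). The two steps that lead to compound 3, a 1.7-fold lower number from compound 1 to compound 3 (0.22 log units; within the scatter) and a 1.4-fold higher number from compound 2 to compound 3 (0.16 log units; within the scatter), both stay within the scatter, so compound 3 sits second highest of the three numbers without being separable from either neighbour.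

Compound 4 `O=C(Nc1cccc(OCc2cn(-c3ccccc3I)nn2)c1)Nc1ccc(Cl)c(C(F)(F)F)c1` differs from compound 3 by iodo in place of bromo on an aromatic carbon. Going by the values given here, none of the measured steps exchanges one halogen for another; the closest in kind is the replacement of one aryl by another, and of those only a 2.4-fold lower number from compound 1 to compound 2 (0.38 log units; beyond the scatter) moved beyond the scatter. The expectation for this assay is therefore a step of a 1.1-fold lower number from compound 3 to compound 4 (0.03 log units; within the scatter), that is no change beyond the scatter. Compound 4 is estimated at 2600 nM, within a range of 1200 nM to 5600 nM.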

Compound 4, half-maximal inhibitory concentration: 2870 nM
The estimate for compound 4 lay 1.1-fold (0.04 log units) below the measured number, within the range that was stated.
By their numbers in this assay, from the lowest: compounds 2, 3, 4 and 1 (each within the scatter of the next, the first and the last beyond it).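

In this assay, for the compounds shown here, exchanging the one halogen for the other on this aromatic carbon, ortho to a large group, gives a 1.0-fold higher number from compound 3 to compound 4 (0.01 log units; within the scatter), so the two halogens cannot be told apart here, and this is the first direct exchange of one halogen for another. The 2-iodophenyl group also cannot be separated from either 4-substituted aryl group, with a 1.5-fold higher number from compound 2 to compound 4 (0.17 log units; within the scatter) and a 1.6-fold lower number from compound 1 to compound 4 (0.21 log units; within the scatter), which places it among the other aryl groups on the triazole nitrogen rather than apart from them. No measurement is available that would explain why this exchange leaves the number in place.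

On these data alone, what an amine or a carboxylic acid on this same aromatic carbon would give remains open, as does whether any group there could produce a step beyond the scatter. The steps from 4-ethylphenyl and 4-methoxyphenyl to 2-iodophenyl also change the group and its place at once, so these compounds cannot separate the contribution of the halogen from that of where it sits on the ring.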